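Furan attachment point: furan-2-yl to furan-3-yl

The compounds below may be only part of what the source reports. "The series", "measured", "known", "first", "only" and "open" are said of these compounds alone.

Compound 2 `CC1=C(C(=O)CC(C)C)C(c2ccco2)NC(=O)N1` stands highest of the two numbers in an assay on membranes from CHO cells for displacement of a labelled ligand from adenosine receptor A1 (Homo sapiens), read by scintillation counting, with a stated time of 60 min, tested at 1 uM (on this read-out lower numbers stand for less inhibition and higher numbers for more inhibition at the one concentration tested (going by the name of the read-out)), where compound 2 gives 16%. Within the data shown here, compound 1 `CC1=C(C(=O)C2CC2)C(c2ccco2)NC(=O)N1` gives 2% in this assay; the one measured step, a number 14 percentage points higher from compound 1 to compound 2 (beyond the scatter), alters the group on a carbonyl carbon and leaves the furan untouched. Compound 3 `CC1=C(C(=O)CC(C)C)C(c2ccoc2)NC(=O)N1` differs from compound 2 in one place: furan-3-yl in place of furan-2-yl on a saturated ring carbon. Among the measured compounds shown here, no measured step bears on this change; the step from compound 1 to compound 2 concerns a different part of the shared core and says nothing about the furan. The expected step in this assay is therefore a number 2 percentage points lower from compound 2 to compound 3 (within the scatter), none beyond the scatter, with the direction left open. Compound 3 is estimated to give 14% in this assay, expected to fall between 0% and 35%.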

Compound 3, a percentage reported as inhibition, at one concentration (the size of the read-out at that concentration, not a potency): 23%
Compound 3: middle estimate off by 9 percentage points, on the low side; the measured number falls inside the stated range.
By their numbers in this assay, from the lowest: compound 1; then compounds 2 and 3 (each within the scatter of the next).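

In this assay, among these compounds, the furan change gives a number 7 percentage points higher from compound 2 to compound 3 (within the scatter) as the first reading at this position. With the isobutylcarbonyl group in place, furan-2-yl and furan-3-yl on this saturated ring carbon cannot be told apart at the one concentration tested, so the attachment point of the furan shows no effect beyond the scatter. The earlier step concerned only the group on the carbonyl carbon, whereas this one shows that the ring carbon bearing the furan can also be read, at least for this swap of two isomeric groups; no evidence at hand bears on this result.

As far as these compounds go, whether the two furans also read alike with cyclopropyl on the carbonyl carbon remains open. So does whether a phenyl or a thiophene ring at this position would shift the number beyond the scatter.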